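A few compounds are considered here, and "the series" means these few. Any claim that something is new, unique, unknown or untested is made for them only; others in the source may bear on it.

Within the data shown here, only two compounds in this small series have been measured so far. In a functional assay on cells (Endothelial cell, Bos taurus) for antiproliferative activity (on this read-out lower numbers stand for stronger inhibition and higher numbers for weaker inhibition), compound 1 `COc1ccc(/C(F)=C/c2cc(OC)c(OC)c(OC)c2)cc1N` gives 111000 nM, while compound 2 `COc1ccc(/C(F)=C\c2cc(OC)c(OC)c(OC)c2)cc1[N+](=O)[O-]` gives 329000 nM. Compound 2 therefore has the higher of the two numbers, meaning the weaker inhibition, and its gap to compound 1 lies beyond the usual scatter.

The next compound to be tested is compound 3 `COc1ccc(/C(F)=C/c2cc(OC)c(OC)c(OC)c2)cc1[N+](=O)[O-]`. Its relation to compound 2 is unusually simple: the two compounds have the same atoms and bonds and differ only in configuration as drawn: 1 of 1 stereo elements differ; a double bond is drawn E in compound 2 and Z in compound 3. In other words, nothing is added or removed, and a double bond is drawn E in compound 2 and Z in compound 3.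

Among the measured compounds shown here, no measured pair here shows what such a change does in this assay, so any forecast is loose. The expectation rests on the two numbers in hand, and compound 3 is expected to stay in the same weak range as compound 2 at 329000 nM. The expected change, a 1.6-fold lower number from compound 2 to compound 3 (0.22 log units; within the scatter), is a small move towards a lower number that does not go beyond the scatter. For compound 3, the estimated value is 200000 nM, with an expected range from 70000 nM to 500000 nM.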

Compound 3, half-maximal inhibitory concentration: > 3000000 nM
Compound 3: a limit, no number (the forecaster's own chance of this, stated with the estimate: 15%); at least 15-fold (1.17 log units) between middle value and limit.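

Among these compounds, until now, no pair of compounds isolated the double bond, but in this assay the read-out moves with its configuration alone, and the step of an at least 9.1-fold higher number from compound 2 to compound 3 (0.95 log units; beyond the scatter) can be credited to that change because nothing else separates the pair: the fact that compounds 2 and 3 differ only in the configuration as drawn. With the drawn configuration held the same, the aromatic group matters too: nitro in place of amino on an aromatic carbon gives an at least 27-fold higher number from compound 1 to compound 3 (1.43 log units; beyond the scatter), so this position also responds clearly to a change of group. The value of compound 3, > 3000000 nM, is a limit of the assay and not a number, so both steps give only a minimum size.

Whether an amino compound responds to a flip of the double bond in the same way as the nitro pair stays open, since the compounds shown include only one amino form. Also open, as far as these compounds go, is how a hydroxyl group, a methylamino group or an acetamide would read at this position on the shared core, and whether any of them would give a lower number than compound 1 at 111000 nM.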